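Series Notes: Hydrogen for Methoxy on the Chain Carbon

The compounds below may be only part of what the source reports. "The series", "measured", "known", "first", "only" and "open" are said of these compounds alone.

Compound 1 `COCC(C(=O)N1CCN(c2cccc(C(F)(F)F)c2)CC1)N1C(=O)CCC1=O` holds the lower of the two measured numbers: in a functional assay on the whole organism (strain Swiss) with Mus musculus as the target, in the maximal electroshock model, with a stated time of 0.5 h, at a dose of 300 mg/kg by the intraperitoneal route (on this read-out lower numbers stand for a weaker effect and higher numbers for a stronger effect at the one dose given), compound 1 gives 50%, whereas compound 2 `CCC(C(=O)N1CCN(c2cccc(C)c2)CC1)N1C(=O)CCC1=O` gives 100%, a gap beyond the usual scatter. Among the measured compounds shown here, these two differ in more than one place, so their values show no single step. Compound 3 `CC(C(=O)N1CCN(c2cccc(C(F)(F)F)c2)CC1)N1C(=O)CCC1=O` is compound 1 with hydrogen in place of methoxy on a saturated chain carbon, two bonds along the chain from an amide-type nitrogen in a ring and a carbonyl carbon. For the measured compounds named here, no measured pair isolates this change. A modest gain in this assay is expected because compound 2 with 100% also carries a shorter chain, though its aryl group differs. Compound 3 is estimated at 70%, range 35% to 100%. The expected step is a number 20 percentage points higher from compound 1 to compound 3 (beyond the scatter).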

Compound 3, a percentage reported as activity, at one dose (the size of the read-out at that dose, not a potency): 100%
Estimate against measurement, compound 3: 30 percentage points below, within the range that was stated.
By their numbers in this assay, from the lowest: compound 1; then compounds 2 and 3 (each within the scatter of the next).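

With the aryl group held constant, hydrogen in place of methoxy on this saturated chain carbon gives a single-change reading at this position: in this assay, a number 50 percentage points higher from compound 1 to compound 3 (beyond the scatter). The methoxymethyl to methyl change thus carries a large step on its own, which the earlier pair could not separate from its other differences. No available measurement gives a reason for the step. Still open, on these data alone, is how a hydroxymethyl or an aminomethyl group on the same carbon would read, and whether the step holds on the core of compound 2.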